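A few compounds are considered here, and "the series" means these few. Any claim that something is new, unique, unknown or untested is made for them only; others in the source may bear on it.

Among the compounds with values here, compound 2 `Cc1cn([C@@H]2O[C@H](CO[Si](C)(C)C(C)(C)C)[C@@]3(OS(=O)(=O)C=C3NCC(=O)C(=O)N3CCC3)[C@H]2O[Si](C)(C)C(C)(C)C)c(=O)n(C)c1=O` gives 65000 nM in a functional assay on HEL cells (Homo sapiens) for cytotoxicity, read by microscopy (on this read-out higher numbers stand for lower toxicity in this test and lower numbers for higher toxicity in this test), and stands at the higher of the two measured numbers, with compound 1 `Cc1cn([C@@H]2O[C@H](CO[Si](C)(C)C(C)(C)C)[C@@]3(OS(=O)(=O)C=C3NCC(N)=O)[C@H]2O[Si](C)(C)C(C)(C)C)c(=O)n(C)c1=O` at 16000 nM as its only neighbour. Within the data shown here, the one measured step, a 4.1-fold higher number from compound 1 to compound 2 (0.61 log units; beyond the scatter), bears on the present change only loosely, since compound 3 `CCOC(=O)NC(=O)NC1=CS(=O)(=O)O[C@@]12[C@@H](CO[Si](C)(C)C(C)(C)C)O[C@@H](n1cc(C)c(=O)n(C)c1=O)[C@@H]2O[Si](C)(C)C(C)(C)C` carries a different replacement: (ethoxycarbonyl)carbamoyl in place of (((azetidin-1-yl)carbonyl)carbonyl)methyl on an amine nitrogen. Among the measured compounds shown here, no measured pair shows an (ethoxycarbonyl)carbamoyl group, so the direction remains open. The expected step of a 1.3-fold lower number from compound 2 to compound 3 (0.11 log units; within the scatter) is therefore small and within the scatter. Compound 3 is estimated at 50000 nM in this assay, with a range from 15000 nM to 150000 nM.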

Compound 3, minimum cytotoxic concentration: 16000 nM
For compound 3 the middle estimate is 3.1-fold (0.49 log units) above the measured one; measured number inside the range.
By their numbers in this assay, from the lowest: compounds 1 and 3 (each within the scatter of the next); then compound 2.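

On an amine nitrogen, (ethoxycarbonyl)carbamoyl in place of (((azetidin-1-yl)carbonyl)carbonyl)methyl gives a 4.1-fold lower number from compound 2 to compound 3 (0.61 log units; beyond the scatter) in this assay, so this replacement does not hold the higher number of compound 2. In place of carbamoylmethyl, the same group gives no change at the digits printed from compound 1 to compound 3 (within the scatter), and so far only the (((azetidin-1-yl)carbonyl)carbonyl)methyl group stands apart at this position. No available measurement explains either step. Whether the azetidine ring alone accounts for the higher number of compound 2 remains open, as does the reading of a carboxylic acid or a longer alkyl chain on this amine nitrogen.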